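A few compounds are considered here, and "the series" means these few. Any claim that something is new, unique, unknown or untested is made for them only; others in the source may bear on it.

Measured in a functional assay on the whole organism for inhibition, with Rattus norvegicus as the target; a higher number here means that more compound is needed for the effect, a lower number that less compound is needed:
Compound 1 `CC(C)c1ccc(OC(C)(Cc2ccc(C(F)(F)F)cc2)C(=O)O)cc1`: < 5 mg/kg, a limit of the assay
Compound 2 `CCCCc1ccc(CC(C)(Oc2ccc(C(C)C)cc2)C(=O)O)cc1`: 1 mg/kg

Going by the values given here, compound 2 gives the only true number in this small set, 1 mg/kg. Compound 1 offers only a limit: the limit of < 5 mg/kg in this assay, at which 1 of the 2 values shown sits.

Compound 3 `COc1ccc(CC(C)(Oc2ccc(C(C)C)cc2)C(=O)O)cc1` has not yet been measured. It departs from compound 2 in one place: methoxy in place of butyl on an aromatic carbon. This puts methoxy in place of butyl on an aromatic carbon, para to a large group.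

Among the compounds with values here, the one measured step that touches this carbon is a step that the limit leaves unreadable from compound 1 to compound 2, with butyl in place of trifluoromethyl. Within the data shown here, its size cannot be read, so it offers no measure for the new change, and no other measured step bears on it. The expectation must therefore start from compound 2 at 1 mg/kg, and it stays loose. A moderate move toward a higher dose seems more likely than none, though the data settle neither its size nor its direction.

The expected move is a 3.0-fold higher number from compound 2 to compound 3 (0.48 log units; beyond the scatter). For compound 3 the estimated value is 3 mg/kg, with an expected range from 0.7 mg/kg to 15 mg/kg.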

Compound 3, dose for half-maximal effect: > 10 mg/kg
Compound 3: no number, only a limit (the forecaster's own chance of this, stated with the estimate: 25%); middle value at least 3.3-fold (0.52 log units) away from the limit.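

In this assay compound 3 gives > 10 mg/kg, which is a limit of the assay and not a number. Even so, this aromatic carbon, para to a large group, now has its first readable step: methoxy in place of butyl gives an at least 10-fold higher number from compound 2 to compound 3 (1.00 log units; beyond the scatter), which lies beyond the scatter and shows that the activity in this assay responds to the group at this position. Methoxy in place of trifluoromethyl on the same carbon gives an at least 2.0-fold higher number from compound 1 to compound 3 (0.30 log units; that floor lies within the scatter), but that floor lies within the scatter, so this step sets no order between the two groups.

Going by these compounds, the true size of both new steps remains unknown, and the step between trifluoromethyl and butyl still cannot be read, which leaves the place of trifluoromethyl relative to butyl and methoxy unsettled. It is also open whether a propyl group, a longer chain such as hexyl, or an amine on this carbon would fit the contrast between butyl and methoxy, so the compounds shown support no trend with chain length.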